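Compound 1 to compound 4: one group exchanged

The source may report more compounds than this note shows. Statements on the series, on what has been measured and on what is new or still open speak of the compounds shown alone.

Compound 1 (`C=C[C@@](C)(/C=C/c1ccc(OS(=O)(=O)C(F)(F)F)cc1)CCC=C(C)C`) is tested in a functional assay on NALM-6 cells (Homo sapiens) for cytotoxicity, with a stated time of 72 h (a lower number here means that less compound is needed, a higher number that more compound is needed for the effect), and has no exact number there. Compound 1 gives > 43400 nM as its result, and that is a limit. Compound 2 (`C=C[C@@](C)(/C=C/c1ccc(OS(=O)(=O)c2ccc(C)cc2)cc1)CCC=C(C)C`) gives > 43400 nM as its result, again a limit. Compound 3 (`C=C[C@@](C)(/C=C/c1ccc(O)cc1)CC/C=C/C(=O)OCC`) gives > 43400 nM as its result, also a limit. All three share one position (the limit of > 43400 nM in this assay, at which 3 of the 3 values shown sit) and none can be ranked against another.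

The change to compound 4 (`C=C[C@@](C)(/C=C/c1ccc(Nc2ccc(Cl)c(F)c2)cc1)CCC=C(C)C`) is (4-chloro-3-fluorophenyl)amino in place of ((trifluoromethyl)sulfonyl)oxy on an aromatic carbon in one place: (4-chloro-3-fluorophenyl)amino in place of ((trifluoromethyl)sulfonyl)oxy on an aromatic carbon, para to a large group. Going by the values given here, one measured step touches the same group, a step that the two limits leave unreadable from compound 1 to compound 2 with 4-methylphenyl in place of trifluoromethyl on a sulfonyl sulfur. Its size cannot be read, so it offers no size to carry over, and what follows is a cautious expectation. The expected move is an at least 2.1-fold lower number from compound 1 to compound 4 (0.33 log units; beyond the scatter) in the direction of less compound needed. Staying at a limit remains quite possible for compound 4. For compound 4 the estimated value is 20000 nM within an expected range of 5000 nM to 43400 nM in this assay at the same exposure time.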

Compound 4, half-maximal effective concentration: > 43400 nM
Compound 4: no number, only a limit; the forecaster's own chance of this, stated with the estimate: 50%; middle value at least 2.1-fold (0.33 log units) away from the limit.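

In this assay compound 4 gives > 43400 nM, which is a limit and not a number. Compound 1 also stands at a limit, so the step between compound 1 and compound 4 cannot be read: the limit of > 43400 nM in this assay, at which 4 of the 4 values shown sit.

The compounds shown leave open how these four rank against one another and which change, if any, would give an exact number in this assay.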